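The source may report more compounds than this note shows. Statements on the series, on what has been measured and on what is new or still open speak of the compounds shown alone.

Measured in a functional assay on A549 cells (Homo sapiens) for antiproliferative activity, read by MTT assay, with a stated time of 48 h; on this read-out lower numbers stand for stronger inhibition and higher numbers for weaker inhibition:
compound 1 `Cc1ccc(C(=O)/C=C/c2cccc(Br)c2Oc2c([N+](=O)[O-])cc(C(F)(F)F)cc2[N+](=O)[O-])cc1`: 6.85 ug/mL
compound 2 `Cc1ccc(C(=O)/C=C/c2cccc(Cl)c2Oc2c([N+](=O)[O-])cc(C(F)(F)F)cc2[N+](=O)[O-])cc1`: 0.95 ug/mL
compound 3 `COc1ccc(C(=O)/C=C/c2cc(Cl)cc(Cl)c2Oc2c([N+](=O)[O-])cc(C(F)(F)F)cc2[N+](=O)[O-])cc1`: 12.6 ug/mL

Compound 1 at 6.85 ug/mL lies within the scatter of compound 3 at 12.6 ug/mL. Compound 2 stands apart, with a 7.2-fold lower number from compound 1 to compound 2 (0.86 log units; beyond the scatter) for chloro in place of bromo on an aromatic carbon.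

Compound 4 `COc1ccc(C(=O)/C=C/c2cccc(Br)c2Oc2c([N+](=O)[O-])cc(C(F)(F)F)cc2[N+](=O)[O-])cc1` keeps the bromo of compound 1 and changes one place: methoxy in place of methyl on an aromatic carbon. This is methoxy in place of methyl on an aromatic carbon, para to a large group. For the measured compounds named here, the one measured step concerns another place, and no measured step covers this change, so its size does not carry over. Going by the values given here, compound 3 is the only measured methoxy compound, and it gives only a loose guide since it also differs from compound 4 in its halogens. The value of compound 3 at 12.6 ug/mL is still within the scatter of compound 1, so no step beyond the scatter is expected in this assay. The estimated step is a 1.2-fold higher number from compound 1 to compound 4 (0.07 log units; within the scatter). Compound 4 is expected at 8 ug/mL, with an estimated range of 3 ug/mL to 20 ug/mL.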

Compound 4, half-maximal inhibitory concentration: 12.7 ug/mL
Estimate against measurement, compound 4: 1.6-fold (0.20 log units) below, and the stated range covers the measured number.
By their numbers in this assay, from the lowest: compound 2; then compounds 1, 3 and 4 (each within the scatter of the next).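

For the compounds shown here, with the bromo held fixed, 4-methylphenyl to 4-methoxyphenyl gives a 1.9-fold higher number from compound 1 to compound 4 (0.27 log units; within the scatter) in this assay, the only measured step at this position. At this position, then, methoxy in place of methyl, which brings in one oxygen and one hydrogen-bond acceptor, produces no difference that can be told from the scatter, whereas the halogen step at the other place, a 7.2-fold lower number from compound 1 to compound 2 (0.86 log units; beyond the scatter), lies beyond it. No measurement on hand bears on the reason for either reading.

On these data alone, it remains open whether methoxy in place of methyl would also stay within the scatter with chloro in place of bromo. Also open, as far as these compounds go, is how a dimethylamino group, a carboxylic acid or a longer chain such as butoxy at this position would read in this assay on the core of compound 1.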